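Triazole amide series: all values at the assay limit so far

This account rests on a few compounds, and the source may have more. Where it says the series, first, only, none or still open, it means among the compounds named here.

Measured compounds:
compound 1 `CC(C)n1ncc2c(C(=O)NCc3cn(-c4ccc(F)cc4)nn3)cccc21` — > 40000 nM
compound 2 `CC(C)n1ncc2c(C(=O)NCc3cn(-c4cccc(Br)c4)nn3)cccc21` — > 40000 nM
compound 3 `CC(C)n1ncc2c(C(=O)NCc3cn(-c4ccc([N+](=O)[O-])cc4)nn3)cccc21` — > 40000 nM

All three have been run in a functional assay on HepG2 cells (Homo sapiens) for inhibition, read by MTT assay, with a stated time of 72 h; on this read-out lower numbers stand for stronger inhibition and higher numbers for weaker inhibition. Compound 2 stands at a limit of this assay, not at a number. Compounds 1 and 3 stand at the same limit, so nothing separates the three: the limit of > 40000 nM in this assay, at which 3 of the 3 values shown sit. The steps among them are accordingly unreadable: a step that the two limits leave unreadable from compound 1 to compound 2, a step that the two limits leave unreadable from compound 1 to compound 3 and a step that the two limits leave unreadable from compound 2 to compound 3 all fall between two limits, and their size cannot be stated.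

The next compound, compound 4 `COc1ccc(Cn2cc(CNC(=O)c3cccc4c3cnn4C(C)C)nn2)cc1`, differs from compound 2 in one place: 4-methoxybenzyl in place of 3-bromophenyl on an aromatic nitrogen.

Within the data shown here, none of the measured steps bears on this change in a readable way, since every one of them joins two limits. Among the measured compounds shown here, there is therefore no measured basis for expecting a step in either direction in this assay; the only evidence is that three aryl variants on the ring nitrogen all sit beyond the range that can be quantified because of the limit of > 40000 nM in this assay, at which 3 of the 3 values shown sit. Compound 4 is expected to behave like its neighbours, with the step that the limit leaves unreadable from compound 2 to compound 4 estimated as none readable. Compound 4 is estimated at 60000 nM, within 20000 nM to 200000 nM, most probably reported again only as a limit.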

Compound 4, half-maximal inhibitory concentration: > 40000 nM
Compound 4: no number, only a limit (the forecaster's own chance of this, stated with the estimate: 80%); the middle value does not contradict the limit.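

In this assay compound 4 gives > 40000 nM, which is a limit and not a number. No new step can be read: the comparisons of compound 4 with compound 1, compound 2 and compound 3 all join two limits. The compounds shown leave open whether any group on the aromatic nitrogen gives a measurable value: the limit of > 40000 nM in this assay, at which 4 of the 4 values shown sit.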